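A Chloro Group Enters: What Cytotoxicity to Expect

This account rests on a few compounds, and the source may have more. Where it says the series, first, only, none or still open, it means among the compounds named here.

Compound 1 `O=C(CSc1snnc1-c1ccc(Br)cc1Br)Nc1ccccc1[N+](=O)[O-]`: in an ADME assay on MT4 cells (Homo sapiens) for cytotoxicity, read by MTT assay, with a stated time of 5 days (a lower number here means that less compound is tolerated, a higher number that more compound is tolerated), compound 1 gives > 235000 nM, which is a limit rather than a number.
Compound 2 `O=C(CSc1snnc1-c1ccc(Br)cc1Br)Nc1ccccc1F`: in this assay compound 2 gives >= 27800 nM, also a limit.
Compound 3 `O=C(CSc1snnc1-c1ccc(Br)cc1Br)Nc1ccccc1`: in this assay compound 3 gives 24800 nM.

Within the data shown here, compound 3 thus holds the only actual number among the three. Compound 4 `O=C(CSc1snnc1-c1ccc(Br)cc1Br)Nc1ccc(Cl)cc1` differs from compound 3 by chloro in place of hydrogen on an aromatic carbon. The measured steps each swap one group for hydrogen: an at least 9.4-fold lower number from compound 1 to compound 3 (0.97 log units; beyond the scatter) and an at least 1.1-fold lower number from compound 2 to compound 3 (0.04 log units; that floor lies within the scatter). Neither step brings a chloro group in, so they bear only loosely on this change. With nothing pointing in a direction, no step beyond the scatter is expected, that is a 1.0-fold higher number from compound 3 to compound 4 (0.00 log units; within the scatter). Compound 4 is therefore estimated at 25000 nM, between 10000 nM and 60000 nM.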

Compound 4, half-maximal cytotoxic concentration: 23300 nM
For compound 4 the middle estimate is 1.1-fold (0.03 log units) above the measured one, within the range that was stated.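

In this assay, among these compounds, chloro on this aromatic carbon, para to a large group, is the first direct test of a substituent at this place, and it gives a 1.1-fold lower number from compound 3 to compound 4 (0.03 log units; within the scatter), so the two values cannot be told apart. The 4-chlorophenyl group in place of 2-fluorophenyl gives an at least 1.1-fold lower number from compound 2 to compound 4 (0.07 log units; that floor lies within the scatter), while in place of 2-nitrophenyl it gives an at least 10-fold lower number from compound 1 to compound 4 (1.00 log units; beyond the scatter). Both steps start from a limit, so each gives only a floor. Going by these compounds, whether an amine or a carboxylic acid at this place would shift the number stays open. No measured property here accounts for what chloro does.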